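This account rests on a few compounds, and the source may have more. Where it says the series, first, only, none or still open, it means among the compounds named here.

Measured so far in an assay on isolated protein with Bile acid receptor (Homo sapiens) as the target; on this read-out lower numbers stand for an effect already at smaller amounts and higher numbers for an effect only at larger amounts of compound:
- compound 1 `COC(=O)/C=C/c1cccc(N(Cc2ccc(/C=C/c3c(F)cccc3F)cc2)C(=O)C(C)C)c1`: compound 1 gives 108 nM
- compound 2 `COC(=O)/C=C/c1cccc(N(Cc2ccc(-c3cccc(C)c3)cc2)C(=O)C2CCCCC2)c1`: compound 2 gives 109 nM
- compound 3 `COC(=O)/C=C/c1cccc(N(Cc2ccc(-c3cccc(C)c3)cc2)C(=O)C(C)C)c1`: compound 3 gives 163 nM

Compound 2 stands second highest of the three numbers; compound 1 sits nearest to it, and the gap to compound 3 is a 1.5-fold higher number from compound 2 to compound 3 (0.17 log units; within the scatter), so all three numbers lie within the scatter of one another. Compound 4 `COC(=O)/C=C/c1cccc(N(Cc2ccc(Br)cc2)C(=O)C2CCCCC2)c1` is not yet measured. The change from compound 2 to compound 4: bromo in place of 3-methylphenyl on an aromatic carbon.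

Among the measured compounds shown here, of the measured steps, only the one at the same aromatic carbon is comparable, a 1.5-fold higher number from compound 1 to compound 3 (0.18 log units; within the scatter), and there one group of several heavy atoms stood in for another of similar count. The other step concerns the carbonyl carbon, a 1.5-fold higher number from compound 2 to compound 3 (0.17 log units; within the scatter), and does not bear on this position. For the measured compounds named here, no measured step removes the whole seven-heavy-atom group and leaves a single atom in its place, so the expectation rests on thin ground. Because the exchange at this position between compound 1 and compound 3 stayed within scatter, a 1.5-fold higher number from compound 1 to compound 3 (0.18 log units; within the scatter), while the present change is far larger, a moderate rise in the number is expected, a 3.7-fold higher number from compound 2 to compound 4 (0.56 log units; beyond the scatter). For compound 4 the estimate is 400 nM, with a range of 150 nM to 1500 nM.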

Compound 4, half-maximal effective concentration: > 1000 nM
Compound 4: a limit, no number; the forecaster's own chance of this, stated with the estimate: 10%; middle value at least 2.5-fold (0.39 log units) away from the limit.
By their numbers in this assay, from the lowest: compounds 1, 2 and 3 (each within the scatter of the next). At a limit, above all of these: compound 4.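

At the aromatic carbon para to a large group, the number in this assay responds strongly to the size of the change: bromo in place of 3-methylphenyl gives an at least 9.1-fold higher number from compound 2 to compound 4 (0.96 log units; beyond the scatter). The earlier exchange at this carbon, between two larger groups, gave only a 1.5-fold higher number from compound 1 to compound 3 (0.18 log units; within the scatter), so compounds 1 to 3 showed no sensitivity at this position; it appears only once a single bromine replaces the whole aryl group. Compound 4 stands at a limit of the assay, not at a number: the limit of > 1000 nM in this assay, at which 1 of the 4 values shown sits.

From the compounds shown here alone, whether a plain phenyl, a short alkyl chain or an amine at this carbon would keep the number near that of compound 2 stays open, and so does the question of whether the ring or the length of the substituent matters. Also open, going by these compounds, is whether bromo has the same effect with isopropyl on the carbonyl carbon, as in compound 3.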